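The compounds below may be only part of what the source reports. "The series", "measured", "known", "first", "only" and "open" are said of these compounds alone.

Compound 1 `CCCCSc1nc(C(C)c2c(F)cccc2Cl)c(C)c(=O)[nH]1`, compound 2 `CCCCSc1nc(C(C)c2c(F)cccc2Cl)c(CC)c(=O)[nH]1` and compound 3 `CCCSc1nc(C(CC)c2c(F)cccc2Cl)c(C)c(=O)[nH]1` were each tested in an ADME assay on MT4 cells (Homo sapiens) for activation, read by MTT assay; on this read-out higher numbers stand for lower toxicity in this test and lower numbers for higher toxicity in this test. Compound 1 reaches only a limit of this assay, giving > 1500 nM. Compound 2 likewise stops at a limit, giving > 3000 nM. Compound 3 also stops at a limit, giving > 3000 nM. Compound 2 differs from compound 1 by methyl in place of hydrogen on a saturated chain carbon bound to an aromatic carbon, and the step that the two limits leave unreadable from compound 1 to compound 2 cannot be sized because compound 1 sits at the limit of > 1500 nM in this assay, at which 1 of the 3 values shown sits, while compound 2 sits at the limit of > 3000 nM in this assay, at which 2 of the 3 values shown sit. The difference between the core of compound 1 and the core of compound 3 is not broken down here. Compound 4 `CCC(C)Sc1nc(C(CC)c2c(F)cccc2Cl)c(C)c(=O)[nH]1` differs from compound 3 by methyl in place of hydrogen on a saturated chain carbon bound to a saturated chain carbon and a sulfur, the same kind of change, but here on a saturated chain carbon bound to a saturated chain carbon and a sulfur rather than one bound to an aromatic carbon. Beside the unreadable earlier step, a step that the limit leaves unreadable from compound 3 to compound 4 is expected, resting on compound 3 standing at the limit of > 3000 nM in this assay, at which 2 of the 3 values shown sit. Compound 4 is therefore estimated at 4000 nM.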

Compound 4, half-maximal cytotoxic concentration: > 3000 nM
Compound 4: no number, only a limit; the forecaster's own chance of this, stated with the estimate: 75%; the middle value lies beyond the limit too.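

Compound 3 and compound 4 both stop at a limit, so the step between them cannot be read. The compounds shown leave open whether methyl in place of hydrogen changes the read-out at all.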